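This account rests on a few compounds, and the source may have more. Where it says the series, first, only, none or still open, it means among the compounds named here.

Compound 1 `O=C(CSC(=S)N[C@H]1CCOC1=O)Nc1ccccc1F` gives 122000 nM in a functional assay on MGC-803 cells (Homo sapiens) for cytotoxicity, read by MTT assay, with a stated time of 72 h; on this read-out higher numbers stand for weaker inhibition and lower numbers for stronger inhibition; compound 2 `O=C(CSC(=S)N[C@H]1CCOC1=O)Nc1ccccc1` gives 39700 nM in this assay; compound 3 `O=C(CCl)Nc1ccc(C(=O)/C=C/c2ccc(F)cc2)cc1` gives 4680 nM in this assay, the lowest of the three numbers.

Compound 1 and compound 2 share a core and differ by fluoro in place of hydrogen on an aromatic carbon. That change produced a 3.1-fold higher number from compound 2 to compound 1 (0.49 log units; beyond the scatter). Compound 3 has a different core; the difference between the two cores is not broken down here. Compound 4 `O=C(CCl)Nc1ccc(C(=O)/C=C/c2ccc(F)c(F)c2)cc1` differs from compound 3 by fluoro in place of hydrogen on an aromatic carbon. Among the measured compounds shown here, this is the same kind of change as the one from compound 2 to compound 1, but not the same: in compound 4 the new fluoro sits ortho to a fluoro group and meta to a large group, whereas in compound 1 it sits ortho to a large group. Resting on the one earlier example, compound 4 is expected to give a step of a 1.4-fold higher number from compound 3 to compound 4 (0.14 log units; within the scatter) in this assay, a somewhat weaker outcome, though the different surroundings and core leave the direction uncertain. Compound 4 is therefore estimated at 6500 nM, between 2500 nM and 17000 nM.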

Compound 4, half-maximal inhibitory concentration: 3190 nM
The estimate for compound 4 lay 2.0-fold (0.31 log units) above the measured number; low and high end bracket the measured number.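

In this assay, fluoro in place of hydrogen on an aromatic carbon gave a 1.5-fold lower number from compound 3 to compound 4 (0.17 log units; within the scatter) and so left the number for the core of compound 3 within the scatter. Among the compounds shown here, with only one step on each core and the new fluoro in a different place on each, these results do not show whether the core or the place of the fluoro accounts for the gap, nor what a third core would give. What they do show is that the step did not carry over unchanged from one core to the other: the same change on two cores in this assay, a 3.1-fold higher number (0.49 log units; beyond the scatter) from compound 2 to compound 1 and a 1.5-fold lower number (0.17 log units; within the scatter) from compound 3 to compound 4, 4.5-fold (0.65 log units) apart, beyond the scatter of two such steps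

The compounds shown leave open what a chloro or a methoxy group would give in place of the new fluoro of compound 4. They also leave open what an amine would give in place of the chlorine of compound 3.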